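Ether chain variation on the shared core: compound 4

A few compounds are considered here, and "the series" means these few. Any claim that something is new, unique, unknown or untested is made for them only; others in the source may bear on it.

Compound 1 `CN(C)CCNc1ccnc2cc(OCc3ccccc3)ccc12` gives 1250 nM in a functional assay on BGC-823 cells (Homo sapiens) for cytotoxicity, read by MTT assay, with a stated time of 48 h (a lower number here means a stronger inhibitor, a higher number a weaker inhibitor), the lowest of the three numbers measured. Compound 2 `Clc1ccnc2cc(OCc3ccccc3)ccc12` gives 5170 nM and compound 3 `CCOc1ccc2c(Cl)ccnc2c1` gives 3910 nM. The step of a 4.1-fold higher number from compound 1 to compound 2 (0.62 log units; beyond the scatter) concerns the amine and does not bear on the ether. The step of a 1.3-fold lower number from compound 2 to compound 3 (0.12 log units; within the scatter) exchanges the same benzyl group that compound 4 `CCCCCCOc1ccc2c(NCCN(C)C)ccnc2c1` alters: here the change is pentyl in place of phenyl on a saturated chain carbon bound to an oxygen on an aromatic ring, benzyloxy to hexyloxy. That earlier exchange of phenyl for methyl at this carbon stayed within the scatter, so for compound 4 no step beyond the scatter is expected in this assay. Compound 4 is estimated at 1300 nM with a range of 500 nM to 3500 nM. The expected step reads a 1.0-fold higher number from compound 1 to compound 4 (0.02 log units; within the scatter).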

Compound 4, half-maximal inhibitory concentration: 1090 nM
For compound 4 the middle estimate is 1.2-fold (0.08 log units) above the measured one, and the stated range covers the measured number.
By their numbers in this assay, from the lowest: compounds 4 and 1 (each within the scatter of the next); then compounds 3 and 2 (each within the scatter of the next).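

With the (2-(dimethylamino)ethyl)amino group kept in place, benzyloxy to hexyloxy gives in this assay a 1.1-fold lower number from compound 1 to compound 4 (0.06 log units; within the scatter) and so stays within the scatter. The earlier exchange of phenyl for methyl was read only between the chloro compounds, compound 2 and compound 3; this step shows the same absence of a clear shift with the amine present, and with pentyl, which has no ring, at this carbon. Nothing measured here explains the result.

Going by these compounds, whether a chain longer than hexyl, or an ether chain ending in an amine or a carboxylic acid, would keep the number in this assay at this level remains open.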